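Cytotoxicity notes on the terminal aryl exchange

The source may hold more compounds than are shown below. What is called first, only, known or untested is meant among the compounds shown, and "the series" means these compounds.

Three compounds of the series share one core and differ only in the terminal aromatic ring. Compound 1 `COc1cc(CC(O)c2ccc(-c3ccc(C=O)cc3)cc2)c([N+](=O)[O-])cc1OC` reaches only a limit in an ADME assay on HeLa Rh cells (Homo sapiens) for cytotoxicity, read by microscopy (on this read-out higher numbers stand for lower toxicity in this test and lower numbers for higher toxicity in this test), and gives > 245000 nM. That value is a limit, not a number (the limit of > 245000 nM in this assay, at which 1 of the 3 values shown sits). Compound 2 `COc1cc(CC(O)c2ccc(-c3cccc(Cl)c3)cc2)c([N+](=O)[O-])cc1OC` gives 5900 nM in this assay. Compound 3 `COc1cc(CC(O)c2ccc(-c3ccccc3CO)cc2)c([N+](=O)[O-])cc1OC` gives 24000 nM in this assay, the highest of the two numbers obtained; its nearest neighbour is compound 2, and the step of a 4.1-fold higher number from compound 2 to compound 3 (0.61 log units; beyond the scatter) lies beyond the scatter. The remaining steps are an at least 41-fold lower number from compound 1 to compound 2 (1.61 log units; beyond the scatter) and an at least 10-fold lower number from compound 1 to compound 3 (1.00 log units; beyond the scatter).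

Compound 4 `COc1cc(CC(O)c2ccc(-c3cccs3)cc2)c([N+](=O)[O-])cc1OC` differs from compound 3 by thiophen-2-yl in place of 2-(hydroxymethyl)phenyl on an aromatic carbon. Going by the values given here, the steps that bear on this change are those that exchange the terminal ring: a 4.1-fold higher number from compound 2 to compound 3 (0.61 log units; beyond the scatter) and an at least 10-fold lower number from compound 1 to compound 3 (1.00 log units; beyond the scatter). In both, the 2-(hydroxymethyl)phenyl ring sits at the upper end of the measured numbers, and replacing it with a ring that carries no hydrogen-bond donor is expected to move this assay down, toward the level of compound 2. Compound 4 is therefore expected to give 7000 nM, with a range from 2500 nM to 25000 nM. The expected step is a 3.4-fold lower number from compound 3 to compound 4 (0.54 log units; beyond the scatter).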

Compound 4, half-maximal cytotoxic concentration: 11000 nM
For compound 4 the middle estimate is 1.6-fold (0.20 log units) below the measured one, and the stated range covers the measured number.
By their numbers in this assay, from the lowest: compounds 2 and 4 (each within the scatter of the next); then compound 3. At a limit, above all of these: compound 1.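

Notes on the thiophen-2-yl exchange: this is the only five-membered terminal ring in the set, and in this assay it separates from the 2-(hydroxymethyl)phenyl ring, a 2.2-fold lower number from compound 3 to compound 4 (0.34 log units; beyond the scatter), yet it cannot be told apart from the 3-chlorophenyl ring, a 1.9-fold higher number from compound 2 to compound 4 (0.27 log units; within the scatter), so the position accepts a five-membered ring with sulfur and a six-membered ring with chlorine at one level. The step of an at least 22-fold lower number from compound 1 to compound 4 (1.34 log units; beyond the scatter) confirms that the 4-formylphenyl ring stands apart from all three other terminal rings, now including a ring of a different size. Compound 1 is held at a limit, which is not a number: the limit of > 245000 nM in this assay, at which 1 of the 4 values shown sits.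

The compounds shown leave open whether the hydroxymethyl group or its placement on the ring sets compound 3 apart from compound 2 and compound 4, and whether the formyl group or its placement sets compound 1 apart, since each group appears at one place only. Also open, on these data alone, is how a terminal ring carrying an amine or a carboxylic acid, or a furan-2-yl ring in place of thiophen-2-yl, would read in this assay.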